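Fluoro step on the cytosine-bearing member of the series

The source may hold more compounds than are shown below. What is called first, only, known or untested is meant among the compounds shown, and "the series" means these compounds.

Measured in a functional assay on CCRF-CEM cells (Homo sapiens) for cytotoxicity; on this read-out lower numbers stand for stronger inhibition and higher numbers for weaker inhibition:
Compound 1 `Cc1cn([C@H]2C=C(F)[C@@H](CO)O2)c(=O)[nH]c1=O`: > 100000 nM, a limit
Compound 2 `O=c1ccn(C2C=C(F)C(CO)O2)c(=O)[nH]1`: > 100000 nM, a limit
Compound 3 `Nc1ccn([C@H]2C=C(F)[C@@H](CO)O2)c(=O)n1`: > 100000 nM, a limit

So far the series offers only (the limit of > 100000 nM in this assay, at which 3 of the 3 values shown sit). Compound 3 therefore has no number, only a limit of > 100000 nM. Compound 4 `Nc1nc(=O)n([C@H]2C=C(F)[C@@H](CO)O2)cc1F` differs from compound 3 by one change: fluoro in place of hydrogen on an aromatic carbon. For the measured compounds named here, no measured pair shows the size of this change. The expectation in this assay is no step beyond the scatter, with any shift more likely towards stronger inhibition. The estimated step is a number no higher from compound 3 to compound 4 (the limit leaves the size open). For compound 4 the expected value is 100000 nM, with an estimated range of 30000 nM to 150000 nM.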

Compound 4, half-maximal inhibitory concentration: > 100000 nM
Compound 4: no number, only a limit (the forecaster's own chance of this, stated with the estimate: 75%); the middle value sits exactly at the limit.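

Compound 3 and compound 4 each carry only a limit, so no step for the fluoro change can be read from this pair: the limit of > 100000 nM in this assay, at which 4 of the 4 values shown sit.

The size and direction of this fluoro step in this assay stay open, with no number for any compound shown.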